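Thiazolyl replacement on the carbonyl carbon of compound 2

The source may report more compounds than this note shows. Statements on the series, on what has been measured and on what is new or still open speak of the compounds shown alone.

Within the data shown here, compound 2 `COc1ccccc1C(=O)C(CSC(=S)N(C)C)CSC(=S)N(C)C` gives 810 nM in a functional assay on NCI-H460 cells (Homo sapiens) for inhibition, read by MTT assay, with a stated time of 72 h (a lower number here means a stronger inhibitor, a higher number a weaker inhibitor), the lowest of the three numbers measured so far. Compound 1 `CN(C)C(=S)SCC(CSC(=S)N(C)C)C(=O)c1ccc(F)cc1` gives 1210 nM; these two values lie within the scatter of each other, so no order between them is claimed. Compound 3 `CN(C)C(=S)SCC(CSC(=S)N(C)C)C(=O)c1ccc(OCc2ccccc2)cc1` gives 9770 nM, the highest number of the set, and its gap to compound 2 is beyond the scatter.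

Among the measured compounds shown here, two steps are known. a 1.5-fold lower number from compound 1 to compound 2 (0.17 log units; within the scatter) is the only complete exchange of the group on the carbonyl carbon so far, and it left the number unchanged within the scatter. an 8.1-fold higher number from compound 1 to compound 3 (0.91 log units; beyond the scatter) raised the number modestly by enlarging that group rather than exchanging it.

Compound 4 `CN(C)C(=S)SCC(CSC(=S)N(C)C)C(=O)c1nccs1` differs from compound 2 by 1,3-thiazol-2-yl in place of 2-methoxyphenyl on a carbonyl carbon. The step from compound 1 to compound 2 bears on this most directly, as a swap of the whole group on the carbonyl carbon, and it was within the scatter; the step from compound 1 to compound 3 is only loosely related. The entering ring is of a kind not yet measured in this series, so the expectation is broad. In this assay compound 4 is expected to give about 1500 nM, within a range of 500 nM to 4500 nM. The expected step of a 1.9-fold higher number from compound 2 to compound 4 (0.27 log units; within the scatter) is estimated to stay within the scatter, the wide range reflecting the absence of any measured analogue with a five-membered aromatic ring in this place.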

Compound 4, half-maximal inhibitory concentration: 840 nM
Beside the measured number, compound 4's estimate is 1.8-fold (0.25 log units) above it; measured number inside the range.
By their numbers in this assay, from the lowest: compounds 2, 4 and 1 (each within the scatter of the next); then compound 3.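

In this assay, the exchange of 2-methoxyphenyl for 1,3-thiazol-2-yl on the carbonyl carbon gives a 1.0-fold higher number from compound 2 to compound 4 (0.02 log units; within the scatter), and the exchange of 4-fluorophenyl for the same group gives a 1.4-fold lower number from compound 1 to compound 4 (0.16 log units; within the scatter), so neither step supports an order among these compounds. This place therefore holds a five-membered aromatic ring with 2 hetero atoms, and a group of 5 heavy atoms in place of 8, without a change beyond the scatter, which extends the earlier finding from six-membered aromatic rings of carbon only. Compound 3 goes against any reading that every aromatic group is equivalent here, and no measurement available on these compounds offers an explanation for the flat result among compounds 1, 2 and 4.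

Still open, from the compounds shown here alone, is whether an aromatic ring on the carbonyl carbon is needed at all, a question that a cyclohexyl ring or a butyl chain in this place would address. Also open, going by these compounds, is how far the group on the aromatic carbon can grow from fluoro towards benzyloxy before the number rises, which an ethoxy group would begin to show.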